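Replacing the amide with a ketone in a furoyl thioxo core

The compounds below may be only part of what the source reports. "The series", "measured", "known", "first", "only" and "open" are said of these compounds alone.

Both measured compounds share one core, a thioxo-imidazolidine bearing a furan-carbonyl group. Compound 1 `N#C/C(=C\N1CCN(C(=O)c2ccco2)C1=S)C(=O)Nc1ccc(Cl)cc1` carries a 4-chlorophenyl on its amide nitrogen, and in a functional assay on CAKI-1 cells (Homo sapiens) for inhibition, read by sulforhodamine B assay, with a stated time of 48 h (a lower number here means a stronger inhibitor of growth, a higher number a weaker inhibitor of growth), compound 1 gives 13200 nM. Compound 2 `N#C/C(=C\N1CCN(C(=O)c2ccco2)C1=S)C(N)=O` has a plain primary amide, and in this assay compound 2 gives 11800 nM. The step of a 1.1-fold lower number from compound 1 to compound 2 (0.05 log units; within the scatter) shows that these two values sit within the scatter of each other, so nothing separates them.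

Compound 3 `N#C/C(=C\N1CCN(C(=O)c2ccco2)C1=S)C(=O)c1ccccc1` differs from compound 2 by phenyl in place of amino on a carbonyl carbon. For the measured compounds named here, the only measured step changed the substituent on the amide nitrogen and gave no shift beyond the scatter, which weakly suggests this end of the molecule tolerates change. Since the amide itself now becomes a ketone, the expected outcome in this assay is a step of a 1.0-fold higher number from compound 2 to compound 3 (0.01 log units; within the scatter), essentially none beyond the scatter, so compound 3 is estimated at 12000 nM, between 4500 nM and 32000 nM.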

Compound 3, concentration for 50% growth inhibition: 12500 nM
Compound 3: the middle estimate sits 1.0-fold (0.02 log units) below what was measured; the range from low to high includes it.
By their numbers in this assay, from the lowest: compounds 2, 3 and 1 (each within the scatter of the next).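

In this assay, putting phenyl in place of amino on a carbonyl carbon gives a 1.1-fold higher number from compound 2 to compound 3 (0.03 log units; within the scatter) and so shows that the group bonded directly to this carbonyl can change, not only what the amide nitrogen carries. Phenyl in place of (4-chlorophenyl)amino gives a 1.1-fold lower number from compound 1 to compound 3 (0.02 log units; within the scatter) and so shows that, among these compounds, a carbonyl carbon without any amide nitrogen still fits the same narrow spread of numbers. Nothing measured here explains why these numbers stay together.

As far as these compounds go, it remains open whether a hydroxyl, a methyl or a longer alkyl chain on this carbonyl carbon would move the number beyond the scatter. From the compounds shown here alone, it is equally open whether a methoxy group or a chlorine on the phenyl of compound 3 would do so.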